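The source may report more compounds than this note shows. Statements on the series, on what has been measured and on what is new or still open speak of the compounds shown alone.

Compound 1 `COc1ccc2c(=O)c(-c3cc(OC)c(OC)cc3OC)coc2c1` is one of three measured compounds. In a functional assay on HUVEC cells (Homo sapiens) for antiproliferative activity, read by MTT assay, with a stated time of 24 h (on this read-out higher numbers stand for weaker inhibition and lower numbers for stronger inhibition), compound 1 gives > 10000 nM, which is a limit of the assay rather than a number. Compound 2 `COc1cc(OC)c(-c2coc3cc(OCc4ccccc4C)ccc3c2=O)cc1OC` gives 4830 nM in this assay. Compound 3 `COc1cc(OC)c(-c2coc3cc(OCc4cccc(Cl)c4)ccc3c2=O)cc1OC` gives > 10000 nM in this assay, again a limit.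

Compound 1 therefore stands only at the limit of > 10000 nM in this assay, at which 2 of the 3 values shown sit. Compound 4 `COc1cc(OC)c(-c2coc3cc(OCc4ccccc4Br)ccc3c2=O)cc1OC` differs from compound 1 in one place: 2-bromophenyl in place of hydrogen on a saturated chain carbon bound to an oxygen on an aromatic ring. The closest measured step is an at least 2.0-fold lower number from compound 1 to compound 2 (0.31 log units; beyond the scatter), while a step that the two limits leave unreadable from compound 1 to compound 3 and an at least 2.0-fold higher number from compound 2 to compound 3 (0.31 log units; beyond the scatter) show that a different ring in the same place can give a weaker result. A 2-bromophenyl group resembles the 2-methylphenyl of compound 2 more than the 3-chlorophenyl of compound 3, so for compound 4 a step of about an at least 2.0-fold lower number from compound 1 to compound 4 (0.30 log units; that floor lies within the scatter) is expected, giving an estimated 5000 nM (range 1800 nM to 14000 nM).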

Compound 4, half-maximal inhibitory concentration: > 10000 nM
Compound 4 gave a limit, no number (the forecaster's own chance of this, stated with the estimate: 35%); at least 2.0-fold (0.30 log units) between middle value and limit.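

In this assay, bromo in place of methyl on the same ring is not an interchangeable swap: an at least 2.0-fold higher number from compound 2 to compound 4 (0.31 log units; beyond the scatter). A group in that ring place therefore does not by itself keep the result of compound 2, as the 2-bromophenyl of compound 4 shows. The steps from compound 1 and compound 3 to compound 4 cannot be read, and compound 2 alone gives a number while the others sit at one limit: the limit of > 10000 nM in this assay, at which 3 of the 4 values shown sit.

From the compounds shown here alone, whether the methyl itself is what counts stays open, as does the effect of a 2-methoxyphenyl or 2-aminophenyl group in this place. Going by these compounds, how compound 1, compound 3 and compound 4 rank among themselves also stays open.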